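This account rests on a few compounds, and the source may have more. Where it says the series, first, only, none or still open, it means among the compounds named here.

Of the compounds shown here, two have been tested in an ADME assay on HepG2 cells (Homo sapiens) for cytotoxicity, with a stated time of 72 h; a higher number here means that more compound is needed for the effect, a lower number that less compound is needed. Compound 1, `Cc1ccc(NC(=O)Nc2cc(C)nc3ccccc23)cc1`, gives only a limit of the assay: in this assay compound 1 gives > 25000 nM. Among the compounds with values here, compound 2, `Cc1cc(NC(=O)Nc2cccc(C(F)(F)F)c2)c2ccccc2n1`, is the only compound with an actual number, and in this assay compound 2 gives 21000 nM. Within the data shown here, with the limit of > 25000 nM in this assay, at which 1 of the 2 values shown sits, no step between compound 1 and compound 2 can be counted, so compound 2 stands alone as the single measured point. Compound 3, `Cc1cc(NC(=O)Nc2cccc(Cl)c2)c2ccccc2n1`, has not yet been measured. Its difference from compound 2 is counted as chloro in place of trifluoromethyl on an aromatic carbon. Among the measured compounds shown here, no step between two measured compounds exists to guide the expectation. In this assay the change is expected to bring no step beyond the usual scatter, and the step of a 1.0-fold higher number from compound 2 to compound 3 (0.02 log units; within the scatter) is expected to be small in either direction. The value expected for compound 3 in this assay is 22000 nM, within a range from 10000 nM to 50000 nM.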

Compound 3, half-maximal effective concentration: 19000 nM
For compound 3 the middle estimate is 1.2-fold (0.06 log units) above the measured one; the measured number falls inside the stated range.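

In this assay, within the data shown here, chloro in place of trifluoromethyl on the aromatic carbon gives a 1.1-fold lower number from compound 2 to compound 3 (0.04 log units; within the scatter), the first step here between two measured numbers. It shows that going from the 4 heavy atoms of trifluoromethyl to the 1 heavy atom of chloro at this position leaves the number within the usual scatter. The second step, with 3-chlorophenyl in place of 4-methylphenyl on the amide-type nitrogen, is an at least 1.3-fold lower number from compound 1 to compound 3 (0.11 log units; that floor lies within the scatter), and it can be read only as a floor, as compound 1 gives a limit of the assay and not a number: the limit of > 25000 nM in this assay, at which 1 of the 3 values shown sits.

The compounds shown leave open whether a group of another kind at this position, such as an amine or a carboxylic acid, would bring a step beyond the scatter. From the compounds shown here alone, with only chloro and trifluoromethyl compared here, it also remains open whether the number stays this steady for other groups, such as a methoxy group or a longer alkyl chain.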